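Methoxy in place of methylpyrazolyl: expectation for compound 4

The compounds below may be only part of what the source reports. "The series", "measured", "known", "first", "only" and "open" are said of these compounds alone.

Compound 3 `Cn1cc(-c2cccc3c2CCC3c2ncc[nH]2)cn1` gives in a functional assay on CHO cells for agonist activity at Alpha-1A adrenergic receptor (Homo sapiens), read by FLIPR and calcium flux (on this read-out lower numbers stand for an effect already at smaller amounts and higher numbers for an effect only at larger amounts of compound), only a limit, > 2900 nM; this is the limit noted in the limit of > 2900 nM in this assay, at which 1 of the 3 values shown sits. Compound 1 `Cc1ccc2c(c1NS(C)(=O)=O)CCC2c1ncc[nH]1` gives 33 nM in this assay, and compound 2 `Clc1ccc2c(c1-c1ccn[nH]1)CCC2c1ncc[nH]1` gives 322 nM. Compound 4 `COc1cccc2c1CCC2c1ncc[nH]1` is not yet measured; it differs from compound 3 by methoxy in place of 1-methyl-1H-pyrazol-4-yl on an aromatic carbon. For the measured compounds named here, no step between measured pairs is available, so the expectation rests on the spread of the three values shown and on the change itself. Compound 4 is expected to give a number rather than a limit, with the step of an at least 8.2-fold lower number from compound 3 to compound 4 (0.91 log units; beyond the scatter) pointing toward smaller amounts. The estimate for compound 4 is 350 nM, within 60 nM to 2000 nM.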

Compound 4, half-maximal effective concentration: 32 nM
Estimate against measurement, compound 4: 11-fold (1.04 log units) above, outside the stated range (below it).
By their numbers in this assay, from the lowest: compounds 4 and 1 (each within the scatter of the next); then compound 2. At a limit, above all of these: compound 3.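

In this assay, for the compounds shown here, methoxy in place of 1-methyl-1H-pyrazol-4-yl on this aromatic carbon gives an at least 90-fold lower number from compound 3 to compound 4 (1.95 log units; beyond the scatter), the first step read across a single place. On an otherwise unchanged core, this position separates a measurable value from none, and the ringless methoxy gives the number. The value of compound 3 is a limit, so the step gives only a minimum size: the limit of > 2900 nM in this assay, at which 1 of the 4 values shown sits.

Going by these compounds, how a hydroxyl, an ethoxy or a dimethylamino group on this carbon would compare with methoxy remains open. Whether the oxygen or the smaller group accounts for the change also remains open.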